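This account rests on a few compounds, and the source may have more. Where it says the series, first, only, none or still open, it means among the compounds named here.

Measured compounds:
Compound 1, `C=C(Br)C(=O)Nc1cccc(-c2cn3nc(-c4cccc(OC)c4)sc3n2)c1`, gives 580 nM in a functional assay on L1210 cells (Mus musculus) for inhibition, read by cell counting, with a stated time of 2 days; on this read-out lower numbers stand for stronger inhibition and higher numbers for weaker inhibition.
Compound 2, `Nc1cccc(-c2cn3c(-c4ccccc4)csc3n2)c1`, gives 85000 nM in this assay.
Compound 3, `C=C(Br)C(=O)Nc1cccc(-c2cn3c(-c4ccccc4)csc3n2)c1`, gives 1300 nM in this assay.

Compound 1 has the lowest number of the three measured compounds, meaning the strongest inhibition of the cell growth here. Compound 3 sits nearest to it, and compound 2 furthest away. The difference between the core of compound 1 and the core of compound 3 is not broken down here.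

Within the pair that shares a core, the change from compound 3 to compound 2 is hydrogen in place of (1-bromoethenyl)carbonyl on a nitrogen on an aromatic ring, and it brought a 65-fold higher number from compound 3 to compound 2 (1.82 log units; beyond the scatter). In plain terms, taking the group off the ring nitrogen and leaving only hydrogen there weakened the inhibition strongly.

The unmeasured compound 4, `COc1cccc(-c2nn3cc(-c4cccc(N)c4)nc3s2)c1`, stands to compound 1 as compound 2 stands to compound 3: the change is hydrogen in place of (1-bromoethenyl)carbonyl on a nitrogen on an aromatic ring, and both place lines read the same word for word, so it is the same change on a different core. Within the data shown here, the expectation is that compound 4 follows the same path, since the only measured instance of this change, from compound 3 to compound 2, gave a large weakening. Compound 4 is therefore expected to show a 66-fold higher number from compound 1 to compound 4 (1.82 log units; beyond the scatter), landing at an estimated 38000 nM, with a likely range from 12000 nM to 120000 nM.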

Compound 4, half-maximal inhibitory concentration: > 250000 nM
Compound 4 gave a limit, no number (the forecaster's own chance of this, stated with the estimate: 10%); middle value at least 6.5-fold (0.81 log units) from the limit.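

Taking off the (1-bromoethenyl)carbonyl group and leaving hydrogen on the nitrogen weakens the inhibition on the core of compound 1 as well, in this assay, with an at least 430-fold higher number from compound 1 to compound 4 (2.63 log units; beyond the scatter). Compound 4 reads > 250000 nM, which is a limit of the assay and not a number. The direction of the change therefore carries over between these two cores, but its size does not, and two cores alone cannot explain the gap or predict what a third core would do: the same change on two cores in this assay, a 65-fold higher number (1.82 log units; beyond the scatter) from compound 3 to compound 2 and an at least 430-fold higher number (2.63 log units; beyond the scatter) from compound 1 to compound 4, at least 6.5-fold (0.81 log units) apart, beyond the scatter of two such steps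

Each step shown removes the whole (1-bromoethenyl)carbonyl group, so it remains open whether a smaller change on the same nitrogen, such as a plain acetyl group or a propenoyl group without the bromine, would keep the inhibition. As far as these compounds go, it also remains open which parts of the core of compound 1 and the core of compound 3 set the two steps apart, as the difference between these cores is not broken down into single changes here.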